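From bromophenyl to piperazine: an expected gain in inhibition

The compounds below may be only part of what the source reports. "The series", "measured", "known", "first", "only" and "open" are said of these compounds alone.

Compound 1 `CC(C)(C)n1cc2c(n1)C(=O)CC1(CCN(C(=O)c3cc(-c4ccc(Br)cc4)nc4ccccc34)CC1)O2` gives 9300 nM
Compound 2 `CC(C)(C)n1cc2c(n1)C(=O)CC1(CCN(C(=O)c3cc(-c4ccc(N)cc4)nc4ccccc34)CC1)O2` gives 970 nM
Compound 3 `CC(C)(C)n1cc2c(n1)C(=O)CC1(CCN(C(=O)c3cc(N4CCNCC4)nc4ccccc34)CC1)O2` is not yet measured

In a functional assay on A549 cells (Homo sapiens) for inhibition, read by MTT assay, with a stated time of 72 h (a lower number here means a stronger inhibitor, a higher number a weaker inhibitor), compound 1 (9300 nM) has the higher of the two measured numbers, which makes it the weaker inhibitor. Compound 3 carries piperazin-1-yl in place of 4-bromophenyl on an aromatic carbon next to the ring nitrogen (piperazin-1-yl in place of 4-bromophenyl on an aromatic carbon). Going by the values given here, one measured step bears on this change, and only loosely: a 9.6-fold lower number from compound 1 to compound 2 (0.98 log units; beyond the scatter), a modest step beyond the scatter, with amino in place of bromo on an aromatic carbon. Among the compounds with values here, compound 2 keeps the aromatic ring that compound 3 gives up, so the data offer no direct precedent. A lower number is therefore expected in this assay, though probably by a smaller margin. The expected change is a 3.7-fold lower number from compound 1 to compound 3 (0.57 log units; beyond the scatter) as an estimate. For compound 3 the estimated value is 2500 nM, within an expected range from 700 nM to 9000 nM.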

Compound 3, half-maximal inhibitory concentration: > 10000 nM
Compound 3: no number, only a limit; the forecaster's own chance of this, stated with the estimate: 8%; middle value at least 4.0-fold (0.60 log units) away from the limit.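

In this assay compound 3 gives only a limit, not a number: the limit of > 10000 nM in this assay, at which 1 of the 3 values shown sits. Against the bromo compound the reading is an at least 1.0-fold higher number from compound 1 to compound 3 (0.03 log units; that floor lies within the scatter), so piperazin-1-yl in place of 4-bromophenyl, on this aromatic carbon next to the ring nitrogen, shows no gain in inhibition. Against the amino compound the reading is an at least 10-fold higher number from compound 2 to compound 3 (1.01 log units; beyond the scatter), so a nitrogen in the group at this position is not enough on its own: compound 2, which keeps the six-membered aromatic ring of carbon only, is clearly the stronger inhibitor.

The compounds shown leave open whether that aromatic ring is what matters, and a 4-(piperazin-1-yl)phenyl group, which holds both the ring and the piperazine, would address this. On these data alone, how far compound 3 lies past its limit also remains unknown.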